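This account rests on a few compounds, and the source may have more. Where it says the series, first, only, none or still open, it means among the compounds named here.

So far, three compounds have been measured in a functional assay on HepG2 cells (Homo sapiens) for inhibition, read by MTT assay, with a stated time of 72 h, tested at 30 uM (on this read-out higher numbers stand for more inhibition of growth at the one concentration tested and lower numbers for less inhibition of growth), and they do not all sit at the same level. Compound 1 (`C=CCc1cc(O)c(O)c(CN2CCC(CCO)CC2)c1`) gives 2.5% and compound 3 (`C#CCOc1ccc(CC=C)cc1O`) gives 1.5% in this test. Compound 2 (`C=CCc1ccc(OCc2cn(-c3ccc(OC)cc3)nn2)c(O)c1`) stands highest of the three at 15.4% and its gaps to compound 1 and compound 3 both lie beyond the usual scatter.

Compound 4 (`C=CCc1ccc(OCc2cn(-c3ccc(Br)cc3)nn2)c(O)c1`) departs from compound 2 in a single place: bromo in place of methoxy on an aromatic carbon (this assay has not yet been run on it). This is bromo in place of methoxy on an aromatic carbon, para to a large group, so that 4-methoxyphenyl becomes 4-bromophenyl. Among the measured compounds shown here, no two measured compounds differ in one place only, which leaves the data without a direct guide to this change. Compound 4 keeps the rest of compound 2, so the expectation starts from compound 2 at 15.4% and not from the other two compounds. The expected change is small and slightly upward, and a number 3.6 percentage points higher from compound 2 to compound 4 (within the scatter) is an estimated step that stays within the scatter. In this assay compound 4 is expected at 19% with 6% and 38% as the estimated ends of its range.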

Compound 4, percent growth inhibition at one concentration: 8.9%
Compound 4: the middle estimate sits 10.1 percentage points above what was measured; measured number inside the range.
By their numbers in this assay, from the lowest: compounds 3, 1, 4 and 2 (each within the scatter of the next, the first and the last beyond it).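

In this assay, the exchange of methoxy for bromo on an aromatic carbon, para to a large group, gives a number 6.5 percentage points lower from compound 2 to compound 4 (within the scatter), the first step among these compounds that can be read at a single place. It shows that 4-methoxyphenyl and 4-bromophenyl cannot be told apart in this test, so the two compounds stand at one level within the usual scatter. At this position, methoxy, with 2 heavy atoms and 1 hydrogen-bond acceptor, can therefore give way to bromo, with 1 heavy atom and 0 hydrogen-bond acceptors, without a step beyond the scatter, and nothing measured here explains why the two compounds read alike.

With one exchange at this place, the compounds shown leave open whether an amine, a carboxylic acid or a nitrile on the same aromatic carbon would also stay within the scatter of compound 2 or would move the number beyond it. They also leave open what a longer chain in place of the allyl group on the shared core would do to growth inhibition in this assay.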